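Trading chloro for trifluoromethyl beside the amide

A few compounds are considered here, and "the series" means these few. Any claim that something is new, unique, unknown or untested is made for them only; others in the source may bear on it.

Compound 1, `CCNC(=O)c1ccc(-c2cc3nnn(C4CCN(c5ncc(CC)cn5)CC4)c3cn2)c(C)c1`, is one of two compounds already measured in a physicochemical assay for solubility, read by HPLC, in phosphate buffer, measured as thermodynamic solubility, with a stated time of 24 h, at pH 6.8; on this read-out higher numbers stand for higher solubility and lower numbers for lower solubility. In this assay compound 1 gives < 90 nM, which is a limit of the assay rather than a number. Compound 2, `CCNC(=O)c1ccc(-c2cc3nnn(C4CCN(c5ncc(CC)cn5)CC4)c3cn2)c(Cl)c1`, differs from compound 1 only by a chloro in place of a methyl on an aromatic carbon, and in this assay compound 2 gives 240 nM. That change brought an at least 2.6-fold higher number from compound 1 to compound 2 (0.42 log units; beyond the scatter). Within the data shown here, compound 2 therefore holds the only true number so far, because the other value is the limit of < 90 nM in this assay, at which 1 of the 2 values shown sits.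

Compound 3, `CCNC(=O)c1ccc(-c2cc3nnn(C4CCN(c5ncc(CC)cn5)CC4)c3cn2)c(C(F)(F)F)c1`, carries the next change at the same aromatic carbon: trifluoromethyl in place of chloro on an aromatic carbon. Among the measured compounds shown here, the one measured step that touches this position, the swap of methyl for chloro, was at least modest and raised the number; the data hold no step that sets a trifluoromethyl against a chloro. The expected step is a 1.4-fold lower number from compound 2 to compound 3 (0.15 log units; within the scatter), taken to stay within or close to the usual scatter. Compound 3 is thus estimated at 170 nM, with a range from 60 nM to 450 nM.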

Compound 3, solubility: 1200 nM
For compound 3 the middle estimate is 7.1-fold (0.85 log units) below the measured one; the measured number lies above the stated range.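

In this assay, among these compounds, trifluoromethyl in place of chloro on this aromatic carbon gives a 5.0-fold higher number from compound 2 to compound 3 (0.70 log units; beyond the scatter), the first step at this position with a true number at both ends. It shows that this carbon can still move the number after the earlier change, in a swap where neither group counts any hydrogen-bond donor or acceptor and the entering group is the larger, with 4 heavy atoms against 1. The order at this carbon now runs from methyl through chloro to trifluoromethyl, and the full span is an at least 13-fold higher number from compound 1 to compound 3 (1.12 log units; beyond the scatter), which is a minimum rather than a measured size, as it rests on: the limit of < 90 nM in this assay, at which 1 of the 3 values shown sits.

From the compounds shown here alone, three groups on one carbon show an order but not what lies behind it, so it remains open whether a nitrile, a methoxy group or an amine here would extend that order or break it. It is also open whether trifluoromethyl would give a similar step with a carboxylic acid in place of the ethylcarbamoyl group, since every compound shown carries that same amide.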